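From 4-methylphenyl to 3-methoxyphenyl on the carbonyl carbon

The source may hold more compounds than are shown below. What is called first, only, known or untested is meant among the compounds shown, and "the series" means these compounds.

In a functional assay on HeLa cells (Homo sapiens) for antiproliferative activity, with a stated time of 48 h (on this read-out higher numbers stand for weaker inhibition and lower numbers for stronger inhibition), compound 1 `C=C(Br)C(=O)Nc1ccc(/C=C/C(=O)c2ccc(I)cc2)cc1` gives 7700 nM and compound 2 `C=C(Br)C(=O)Nc1ccc(/C=C/C(=O)c2ccc(C)cc2)cc1` gives 2100 nM as the lower of the two numbers. Among the measured compounds shown here, the only measured step is a 3.7-fold lower number from compound 1 to compound 2 (0.56 log units; beyond the scatter) with methyl in place of iodo on an aromatic carbon. The next compound is compound 3 `C=C(Br)C(=O)Nc1ccc(/C=C/C(=O)c2cccc(OC)c2)cc1` with 3-methoxyphenyl in place of 4-methylphenyl on a carbonyl carbon. For the measured compounds named here, no measured compound carries a methoxy group, so the step from compound 1 gives only a rough scale for the change and little guidance on direction. Going by the values given here, with a 3.7-fold lower number from compound 1 to compound 2 (0.56 log units; beyond the scatter) as the sole guide, a change no larger than that modest step is expected, leaning slightly toward a higher number. The expected step is a 1.4-fold higher number from compound 2 to compound 3 (0.15 log units; within the scatter) in this estimate. For compound 3 the estimated value is 3000 nM with an expected range from 1000 nM to 9000 nM in this assay.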

Compound 3, half-maximal inhibitory concentration: 700 nM
For compound 3 the middle estimate is 4.3-fold (0.63 log units) above the measured one, and the stated range ends above it.
By their numbers in this assay, from the lowest: compound 3; then compound 2; then compound 1.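

In this assay the aryl group on the carbonyl carbon proves able to shift the number further than the iodo-to-methyl exchange did: 3-methoxyphenyl in place of 4-methylphenyl gives a 3.0-fold lower number from compound 2 to compound 3 (0.48 log units; beyond the scatter) and in place of 4-iodophenyl gives an 11-fold lower number from compound 1 to compound 3 (1.04 log units; beyond the scatter) in this series. Compound 3 therefore has the lowest number of the three, and the entering group is the only one here that carries a hydrogen-bond acceptor. No measurement shown here accounts for this gain.

3-Methoxyphenyl differs from 4-methylphenyl in both the substituent and its place on the ring, so the compounds shown do not separate these two changes. Open too, on these data alone, is how 4-methoxyphenyl, 3-methylphenyl, or a ring bearing a hydroxyl or an amine would read out at this position.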